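Dechlorination on the hydrazone aryl of an inactive pair

This account rests on a few compounds, and the source may have more. Where it says the series, first, only, none or still open, it means among the compounds named here.

compound 1 `COc1ccc(OC)c(/C=C/c2nnc(Nc3ccc(Cl)cc3)o2)c1`: > 100000 nM
compound 2 `COc1ccc(OC)c(/C=C/C(=O)N/N=C/c2ccc(Cl)cc2)c1`: > 100000 nM

In a functional assay on T47D cells (Homo sapiens) for antiproliferative activity, read by sulforhodamine B assay, with a stated time of 48 h (a higher number here means a weaker inhibitor of growth, a lower number a stronger inhibitor of growth), compound 1 gives only a limit, not a number. Compound 2 likewise gives only a limit in this assay and stands at the limit of > 100000 nM in this assay, at which 2 of the 2 values shown sit. Compound 3 `COc1ccc(OC)c(/C=C/C(=O)N/N=C/c2ccccc2)c1` differs from compound 2 by hydrogen in place of chloro on an aromatic carbon. Going by the values given here, no step between measured compounds is available, so the effect of this change cannot be read from the series. Because compound 2 sits at the limit of > 100000 nM in this assay, at which 2 of the 2 values shown sit, no step beyond the scatter is expected in either direction. The expected step of a number no higher from compound 2 to compound 3 (the limit leaves the size open) is essentially none. Compound 3 is estimated at 100000 nM, with a range of 30000 nM to 300000 nM.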

Compound 3, concentration for total growth inhibition: > 100000 nM
Compound 3: only a limit was reported; the forecaster's own chance of this, stated with the estimate: 85%; the middle value lies on the limit itself.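

No step can be read from compound 2 to compound 3, since both results are limits: the limit of > 100000 nM in this assay, at which 3 of the 3 values shown sit.

The compounds shown leave open how 4-chlorophenyl to phenyl affects growth inhibition in any compound that gives a number.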